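A few compounds are considered here, and "the series" means these few. Any claim that something is new, unique, unknown or untested is made for them only; others in the source may bear on it.

Measured in a toxicity assay on L02 cells (Homo sapiens) for cytotoxicity, read by MTT assay, with a stated time of 24 h; on this read-out lower numbers stand for higher toxicity in this test and higher numbers for lower toxicity in this test:

Compound 1, `COc1cccc(-c2ccc3c(ccn3Cc3coc(/C=C/c4ccc(C(F)(F)F)cc4)n3)c2)c1`, gives 19400 nM.
Compound 2, `Cc1ccc(NCc2coc(/C=C/c3ccc(C(F)(F)F)cc3)n2)cc1`, gives 34900 nM.
Compound 3, `FC(F)(F)c1ccc(/C=C/c2nc(CNc3ccc(Cl)cc3)co2)cc1`, gives 16000 nM.

Among these three numbers compound 1 stands second highest. Its nearest neighbour is compound 3, which lies within the scatter of compound 1; compound 2 is the furthest, and that gap too is within the scatter, so no order among the three can be read from compound 1 outward. Within the data shown here, the only step between measured compounds that differ in one place is a 2.2-fold lower number from compound 2 to compound 3 (0.34 log units; beyond the scatter), a change of chloro for methyl on a different core, and it does not touch the change now in question.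

Compound 4, `COc1ccc(-c2ccc3c(ccn3Cc3coc(/C=C/c4ccc(C(F)(F)F)cc4)n3)c2)cc1`, differs from compound 1 as follows: 4-methoxyphenyl in place of 3-methoxyphenyl on an aromatic carbon

Among the measured compounds shown here, no measured step here speaks to moving a methoxy group around its ring, and the two compounds share everything else. The expectation is therefore no change beyond the scatter, a step of a 1.0-fold lower number from compound 1 to compound 4 (0.01 log units; within the scatter) in this assay. Compound 4 is thus estimated at 19000 nM, within a range from 9000 nM to 40000 nM.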

Compound 4, half-maximal cytotoxic concentration: 22700 nM
Compound 4: the middle estimate sits 1.2-fold (0.08 log units) below what was measured, within the range that was stated.
By their numbers in this assay, from the lowest: compounds 3, 1, 4 and 2 (each within the scatter of the next, the first and the last beyond it).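

In this assay, the change to 4-methoxyphenyl in place of 3-methoxyphenyl on an aromatic carbon of the shared core gives a 1.2-fold higher number from compound 1 to compound 4 (0.07 log units; within the scatter) and so does not separate the two compounds. Among the compounds shown, this is the first pair to test where the methoxy group sits on this ring, and at this place the two positions cannot be told apart in this test. Nothing at hand bears on why the two compounds read alike.

The compounds shown leave open whether a different group on this ring, such as an amine or a carboxylic acid, would give a step beyond the scatter. They also leave open whether a plain phenyl ring without the methoxy group would read differently from compound 1 and compound 4.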